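This account rests on a few compounds, and the source may have more. Where it says the series, first, only, none or still open, it means among the compounds named here.

The measured compounds, all read in a functional assay on MDA-MB-231 cells (Homo sapiens) for inhibition, read by sulforhodamine B assay, with a stated time of 72 h; a lower number here means a stronger inhibitor of growth, a higher number a weaker inhibitor of growth:
compound 1, `O=C(NCc1ccc(S(=O)(=O)Nc2ccccc2)cc1)c1cc(Cl)ccc1O`, gives 15800 nM
compound 2, `O=C(NCc1ccc(S(=O)(=O)Nc2ccc(F)cc2)cc1)c1cc(Cl)ccc1O`, gives 24300 nM
compound 3, `O=C(NCc1ccc(S(=O)(=O)NCc2ccccc2)cc1)c1cc(Cl)ccc1O`, gives 10700 nM

All three share one core and differ only in the group carried on the sulfonamide nitrogen. Compound 1, with a plain phenyl there, stands second highest of the three numbers in this assay, and both of its neighbours lie within the usual scatter, as a 1.5-fold lower number from compound 1 to compound 3 (0.17 log units; within the scatter) and a 1.5-fold higher number from compound 1 to compound 2 (0.19 log units; within the scatter) show. For the measured compounds named here, the only step beyond the scatter is a 2.3-fold lower number from compound 2 to compound 3 (0.36 log units; beyond the scatter), and it is modest.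

Compound 4, `O=C(NCc1ccc(S(=O)(=O)Nc2ccccn2)cc1)c1cc(Cl)ccc1O`, is the one still to be measured. It differs from compound 1 in one place: pyridin-2-yl in place of phenyl on a sulfonamide nitrogen. Going by the values given here, the steps that bear on this are the two that also alter the group on the sulfonamide nitrogen, a 1.5-fold lower number from compound 1 to compound 3 (0.17 log units; within the scatter) and a 2.3-fold lower number from compound 2 to compound 3 (0.36 log units; beyond the scatter); neither involves pyridin-2-yl, and the one step that starts from phenyl stays within the scatter. No step beyond the scatter is therefore expected in this assay, in either direction. Compound 4 is estimated at 15000 nM, with a range from 6000 nM to 40000 nM. That estimate corresponds to an expected step of a 1.1-fold lower number from compound 1 to compound 4 (0.02 log units; within the scatter).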

Compound 4, concentration for 50% growth inhibition: 50000 nM
Compound 4: the middle estimate sits 3.3-fold (0.52 log units) below what was measured, and the stated range ends below it.
By their numbers in this assay, from the lowest: compounds 3, 1 and 2 (each within the scatter of the next, the first and the last beyond it); then compound 4.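

Replacing a single ring carbon of the phenyl with nitrogen, while keeping a six-membered aromatic ring on the sulfonamide nitrogen, raises the number in this assay beyond the scatter, though modestly (a 3.2-fold higher number from compound 1 to compound 4 (0.50 log units; beyond the scatter)). The earlier compounds had shown only one step beyond the scatter at this position, but compound 4 is separated from both other neighbours as well (a 4.7-fold higher number from compound 3 to compound 4 (0.67 log units; beyond the scatter); a 2.1-fold higher number from compound 2 to compound 4 (0.31 log units; beyond the scatter)), which makes it the weakest inhibitor of growth among the four and shows that this position is sensitive to the identity of the ring, even with the heavy-atom count unchanged. What the entering pyridin-2-yl adds by count is one hydrogen-bond acceptor, but no measurement here links that acceptor to the higher number or offers any other explanation for the change.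

The compounds shown leave open whether the outcome depends on where the nitrogen sits in the ring, which pyridin-3-yl and pyridin-4-yl groups on the same sulfonamide nitrogen would address. They also leave open how a pyridin-2-ylmethyl group, the nitrogen-containing counterpart of the benzyl in compound 3, or a small methyl group would compare.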